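Cyclopropyl amide series: methoxy substitution next to the sulfonamide

A few compounds are considered here, and "the series" means these few. Any claim that something is new, unique, unknown or untested is made for them only; others in the source may bear on it.

Measured compounds:
compound 1 `CC(C)(C)c1ccc(CNC(=O)C(C)(C)c2ccc(NS(C)(=O)=O)c(F)c2)cc1` gives 467 nM
compound 2 `CC(C)(C)c1ccc(CNC(=O)C2(c3ccc(NS(C)(=O)=O)cc3)CC2)cc1` gives 1770 nM

Compound 2 holds the highest of the two numbers in a functional assay on CHO cells for antagonist activity at transient receptor potential cation channel subfamily V member 1 (Rattus norvegicus); on this read-out higher numbers stand for weaker inhibition and lower numbers for stronger inhibition; compound 1 sits at a lower number, and the gap between the two is beyond the scatter. Compound 1 and compound 2 differ in more than one place, so the two values show only where each stands, not what any single change does.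

Compound 3 `COc1cc(C2(C(=O)NCc3ccc(C(C)(C)C)cc3)CC2)ccc1NS(C)(=O)=O` is the next member. It carries methoxy in place of hydrogen on an aromatic carbon, with the change on an aromatic carbon of the six-membered aromatic ring of carbon only, ortho to the methanesulfonamido group and meta to the large group. Among the measured compounds shown here, no step between measured compounds addresses a substituent at this position on the cyclopropyl core, so the expectation rests on the position of compound 2 alone. Compound 3 is expected to move to a somewhat lower number, with the step of a 2.0-fold lower number from compound 2 to compound 3 (0.29 log units; within the scatter) estimated as moderate and not certain to clear the scatter. Compound 3 is estimated at 900 nM, in a range from 300 nM to 3000 nM.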

Compound 3, inhibition constant: 2250 nM
The estimate for compound 3 lay 2.5-fold (0.40 log units) below the measured number, and the stated range covers the measured number.
By their numbers in this assay, from the lowest: compound 1; then compounds 2 and 3 (each within the scatter of the next).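

In this assay, methoxy in place of hydrogen on an aromatic carbon, ortho to a methanesulfonamido group and meta to a large group, gives a 1.3-fold higher number from compound 2 to compound 3 (0.10 log units; within the scatter). Among the compounds shown here, this is the first step that isolates a single place, and it shows that this position can carry methoxy with no difference from hydrogen that can be told from the scatter, so this change offers no evidence of a gain or a loss in this read-out. No measurement on hand bears on why the two compounds read alike.

Still open, on these data alone, is whether a different group at the same position, such as a hydroxyl, an amine or a longer alkoxy chain like ethoxy, would give a step beyond the scatter, since a single substituent cannot define what the position allows. Also open, as far as these compounds go, is whether methoxy would give a similar result on the core of compound 1, which differs from compound 2 and compound 3 in more than one place and so cannot be compared with them directly.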